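Chloro Added to the Phenyl Ring: What to Expect

The source may hold more compounds than are shown below. What is called first, only, known or untested is meant among the compounds shown, and "the series" means these compounds.

Compound 1 `Fc1ccc2[nH]c(-c3nc(-c4ccccc4)no3)cc2c1`: 10800 nM in a functional assay on COLO 320 cells (Homo sapiens) for antiproliferative activity, read by WST assay, with a stated time of 72 h; a higher number here means a weaker inhibitor, a lower number a stronger inhibitor
Compound 2 `O=[N+]([O-])c1ccc2[nH]c(-c3nc(-c4ccccc4)no3)cc2c1`: 12500 nM in this assay
Compound 3 `Clc1ccc2[nH]c(-c3nc(-c4ccccc4)no3)cc2c1`: 16500 nM in this assay

Compound 2 sits among the other two without any separation beyond the scatter: the step of a 1.2-fold higher number from compound 1 to compound 2 (0.06 log units; within the scatter) and the step of a 1.3-fold higher number from compound 2 to compound 3 (0.12 log units; within the scatter) are both small, as is a 1.5-fold higher number from compound 1 to compound 3 (0.18 log units; within the scatter). Compound 4 `O=[N+]([O-])c1ccc2[nH]c(-c3nc(-c4ccc(Cl)cc4)no3)cc2c1` differs from compound 2 by chloro in place of hydrogen on an aromatic carbon. Among the compounds with values here, none of the measured steps touches the phenyl ring; each swaps the group on the other ring of the shared core, and each stays within the scatter. Within the data shown here, no measured step therefore bears directly on this change, and the expectation is a step of no more than the usual scatter in this assay. The change from compound 2 to compound 4 is expected to be no change at the digits printed from compound 2 to compound 4 (within the scatter). Compound 4 is estimated at 12500 nM, with a range from 5000 nM to 31000 nM.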

Compound 4, half-maximal inhibitory concentration: 7700 nM
Compound 4: middle estimate off by 1.6-fold (0.21 log units), on the high side, within the range that was stated.
By their numbers in this assay, from the lowest: compounds 4, 1, 2 and 3 (each within the scatter of the next, the first and the last beyond it).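

Compound 4 is the only compound shown with anything on the phenyl ring, so it gives the first reading at this position. In this assay, chloro para to a large group gives a 1.6-fold lower number from compound 2 to compound 4 (0.21 log units; within the scatter), so this position carries a chlorine without a step beyond the scatter. Nothing available explains this small step. As far as these compounds go, it remains open whether an amine or a carboxylic acid at this position would give a step beyond the scatter. From the compounds shown here alone, it is also open whether chloro here would give a similar step with fluoro in place of the nitro group on the other ring.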